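The source may report more compounds than this note shows. Statements on the series, on what has been measured and on what is new or still open speak of the compounds shown alone.

In a functional assay on MDA-MB-231 cells (Homo sapiens) for cytotoxicity, read by MTT assay, with a stated time of 48 h (a higher number here means a weaker inhibitor, a lower number a stronger inhibitor), compound 1 `c1ccc(-c2nc(-c3c[nH]c4ccccc34)co2)cc1` gives 171000 nM. In this assay compound 2 `Cc1nc(-c2c[nH]c3ccccc23)co1` gives 103000 nM, and compound 3 `COc1ccc(-c2nc(-c3c[nH]c4ccccc34)co2)cc1OC` gives 103000 nM. For the measured compounds named here, the only step measured between single-point neighbours is a 1.7-fold lower number from compound 1 to compound 2 (0.22 log units; within the scatter), methyl in place of phenyl on an aromatic carbon. Compound 2 thus stands level with compound 3 at the digits given and within the scatter of compound 1; none of the three numbers is separated from another beyond the scatter.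

Compound 4 `Oc1ccc(-c2nc(-c3c[nH]c4ccccc34)co2)cc1` has not yet been measured. (4-hydroxyphenyl in place of methyl on an aromatic carbon). The step that bears on this change runs the other way, phenyl to methyl, a 1.7-fold lower number from compound 1 to compound 2 (0.22 log units; within the scatter), and lay within the scatter; compound 3, which carries a substituted phenyl in the same position, shows the same number as compound 2. Putting a phenyl ring back in place of methyl is therefore expected to move the number little, a 1.1-fold higher number from compound 2 to compound 4 (0.03 log units; within the scatter), with no direction beyond the scatter. Compound 4 is expected to give 110000 nM, within the range 55000 nM to 220000 nM.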

Compound 4, half-maximal inhibitory concentration: 103000 nM
The estimate for compound 4 lay 1.1-fold (0.03 log units) above the measured number, within the range that was stated.
By their numbers in this assay, from the lowest: compounds 2, 3, 4 and 1 (each within the scatter of the next).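

In this assay the swap of methyl for 4-hydroxyphenyl, on the aromatic carbon next to the ring nitrogen and next to the ring oxygen, gives no change at the digits printed from compound 2 to compound 4 (within the scatter) even though an aromatic ring, a hydrogen-bond donor and a hydrogen-bond acceptor all enter there. Hydroxy in place of hydrogen on the phenyl ring gives a 1.7-fold lower number from compound 1 to compound 4 (0.22 log units; within the scatter) and is the first single-substituent change read on that ring, though it does not separate the two compounds. No measurement available here explains why the numbers stay so close.

Still open, from the compounds shown here alone, is whether an amine or a carboxylic acid on the phenyl ring, or a longer chain in place of methyl, would move the number beyond the scatter. Going by these compounds, the shared core is unchanged throughout, so its own part in the result also remains unknown.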